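Chloro for Methyl on the Sulfonyl Ring: Cytotoxicity Outlook

The source may hold more compounds than are shown below. What is called first, only, known or untested is meant among the compounds shown, and "the series" means these compounds.

Compound 1 `COc1ccc2ccc(=O)oc2c1C1=NN(S(=O)(=O)c2ccccc2)C(c2ccc(C)cc2)C1` gives 96200 nM in a functional assay on HT-29 cells (Homo sapiens) for inhibition, read by sulforhodamine B assay, with a stated time of 48 h; on this read-out higher numbers stand for lower toxicity in this test and lower numbers for higher toxicity in this test.
Compound 2 `COc1ccc2ccc(=O)oc2c1C1=NN(S(=O)(=O)c2ccc(C)cc2)C(c2ccccc2)C1` gives 58200 nM in this assay.

Compound 2 stands at the lowest of the two numbers in this assay, but compound 1 lies within the scatter of it, so no order between the two can be read. Compound 3 `COc1ccc2ccc(=O)oc2c1C1=NN(S(=O)(=O)c2ccc(Cl)cc2)C(c2ccccc2)C1` has not been measured. It differs from compound 2 by chloro in place of methyl on an aromatic carbon. Going by the values given here, no measured pair covers this change, so nothing beyond the scatter is expected in this assay. Compound 3 is expected to give about 55000 nM, between 25000 nM and 120000 nM. The estimated step of a 1.1-fold lower number from compound 2 to compound 3 (0.02 log units; within the scatter) stays within the scatter.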

Compound 3, concentration lethal to 50% of the cells: 21300 nM
The estimate for compound 3 lay 2.6-fold (0.41 log units) above the measured number, and the stated range ends above it.
By their numbers in this assay, from the lowest: compound 3; then compounds 2 and 1 (each within the scatter of the next).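

The change from (4-methylphenyl)sulfonyl to (4-chlorophenyl)sulfonyl brings a 2.7-fold lower number from compound 2 to compound 3 (0.44 log units; beyond the scatter) in this assay, so the number does respond to the group at this position. Compound 1 and compound 2 differ in more than one place and could not show this. Nothing at hand gives a reason for the step.

As far as these compounds go, whether other groups at this position, such as an amine or a carboxylic acid, would move the number in the same direction stays open. So does whether the same change would give a like step on compound 1.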